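This account rests on a few compounds, and the source may have more. Where it says the series, first, only, none or still open, it means among the compounds named here.

Measured compounds:
- Compound 1 `COC(=O)c1cc(-c2cccc(NC(=O)c3ccc(/C=C/C(=O)c4cc(OC)c(OC)c(OC)c4)cc3)c2)on1`: in an ADME assay on Vero cells (Chlorocebus sabaeus) for cytotoxicity, read by MTT assay, with a stated time of 72 h (on this read-out lower numbers stand for higher toxicity in this test and higher numbers for lower toxicity in this test), compound 1 gives > 50 ug/mL, which is a limit of the assay rather than a number.
- Compound 2 `COC(=O)c1cc(-c2cccc(NC(=O)c3ccc(/C=C/C(=O)c4ccc(C)c(F)c4)cc3)c2)on1`: in this assay compound 2 gives > 50 ug/mL, also a limit.
- Compound 3 `COC(=O)c1cc(-c2cccc(NC(=O)c3ccc(/C=C/C(=O)c4ccc(OC)cc4OC)cc3)c2)on1`: in this assay compound 3 gives > 50 ug/mL, again a limit.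

Compound 3 therefore stands exactly where the other two measured compounds stand: at the limit, with no resolved number, as summarised by the limit of > 50 ug/mL in this assay, at which 3 of the 3 values shown sit. The three compounds share one core and differ only in the aryl group on the carbonyl carbon. The steps between them, a step that the two limits leave unreadable from compound 1 to compound 2, a step that the two limits leave unreadable from compound 1 to compound 3 and a step that the two limits leave unreadable from compound 2 to compound 3, are all unreadable: each end is a limit, so neither size nor direction can be taken from them.

Compound 4 `COC(=O)c1cc(-c2cccc(NC(=O)c3ccc(/C=C/C(=O)c4ccc([N+](=O)[O-])cc4)cc3)c2)on1` has not been measured in this assay. It differs from compound 3 as 4-nitrophenyl in place of 2,4-dimethoxyphenyl on a carbonyl carbon. The measured steps bear on this change only in a weak way: three different aryl groups at the same place all left the compound at the limit, and none gives a readable size. The expected step from compound 3 is therefore a step that the limit leaves unreadable from compound 3 to compound 4, with no direction beyond the scatter claimed. Compound 4 is expected to give about 60 ug/mL, within a range from 25 ug/mL to 150 ug/mL, most likely reported again as a limit.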

Compound 4, half-maximal cytotoxic concentration: > 20 ug/mL
Compound 4 ended at the assay's limit; the forecaster's own chance of this, stated with the estimate: 70%; the middle value is on the limit's open side.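

In this assay compound 4 gives > 20 ug/mL, which is a limit of the assay rather than a number. Within the data shown here, compound 1, compound 2 and compound 3 also sit at a limit, so no step from any of them to compound 4 can be read. The compounds shown leave open whether changing the aryl group on the carbonyl carbon alters the toxicity at all, and if so, in which direction and by how much.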